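Trifluoromethyl in Place of Hydrogen on the Shared Core

A few compounds are considered here, and "the series" means these few. Any claim that something is new, unique, unknown or untested is made for them only; others in the source may bear on it.

In a functional assay on HCT-116 cells (Homo sapiens) for cytotoxicity, read by MTT assay, with a stated time of 48 h, in the presence of a further agent that is not named here (a lower number here means that less compound is needed, a higher number that more compound is needed for the effect), compound 1 `CCCc1cc(NNC(=O)Nc2cc(Cl)nc(Cl)c2)nc2c1c(C)nn2C` gives 72200 nM and compound 2 `CCCc1cc(NNC(=O)Nc2cc(Cl)nc(Cl)c2)nc2c1cnn2C` gives 76200 nM, so compound 2 stands level with compound 1 within the scatter. Compound 3 `CCCc1cc(NNC(=O)Nc2cc(Cl)nc(Cl)c2)nc2c1c(C(F)(F)F)nn2C` carries trifluoromethyl in place of hydrogen on an aromatic carbon of the shared core: trifluoromethyl in place of hydrogen on an aromatic carbon. Among the compounds with values here, the only measured step at this carbon, between methyl and hydrogen, is a 1.1-fold higher number from compound 1 to compound 2 (0.02 log units; within the scatter). Within the data shown here, no measured compound carries trifluoromethyl, so the expectation remains loose, and no step beyond the scatter is expected in this assay. The expected step is a 1.1-fold lower number from compound 2 to compound 3 (0.04 log units; within the scatter). Compound 3 is estimated at 70000 nM, with an expected range of 30000 nM to 150000 nM.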

Compound 3, half-maximal effective concentration: 38200 nM
Compound 3: middle estimate off by 1.8-fold (0.26 log units), on the high side, within the range that was stated.
By their numbers in this assay, from the lowest: compounds 3, 1 and 2 (each within the scatter of the next).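

In this assay, trifluoromethyl on this aromatic carbon gives a 2.0-fold lower number from compound 2 to compound 3 (0.30 log units; within the scatter) and a 1.9-fold lower number from compound 1 to compound 3 (0.28 log units; within the scatter) as its two steps. This carbon has now carried hydrogen, methyl and trifluoromethyl, and even the entry of 4 heavy atoms leaves every step here within the scatter. Nothing available bears on why these numbers lie so close together. The compounds shown leave open whether an amine, a carboxylic acid or a longer chain on this carbon would give a step beyond the scatter. They also leave open whether this flat picture holds in any other setting.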